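This account rests on a few compounds, and the source may have more. Where it says the series, first, only, none or still open, it means among the compounds named here.

Measured in a functional assay on HCT-116 cells (Homo sapiens) for inhibition, read by MTT assay, with a stated time of 48 h; a lower number here means a stronger inhibitor, a higher number a weaker inhibitor:
Compound 1 `Cc1nnsc1CO/N=C/c1c(C)nn(C)c1Oc1ccccc1Cl`: 42500 nM
Compound 2 `Cc1nnsc1CO/N=C/c1c(C)nn(C)c1Oc1cccc(F)c1`: > 50000 nM
Compound 3 `Cc1cccc(Oc2c(/C=N/OCc3snnc3C)c(C)nn2C)c1`: 14100 nM

Compound 2 has no numerical value, and its entry of > 50000 nM is a limit of the assay. Any step that starts from compound 2 is therefore known only as a bound.

Compound 4 `Cc1ccc(Oc2c(/C=N/OCc3snnc3C)c(C)nn2C)cc1` has not yet been measured. Its difference from compound 2 is 4-methylphenyl in place of 3-fluorophenyl on an oxygen on an aromatic ring. In short, 4-methylphenyl stands in place of 3-fluorophenyl on an oxygen on an aromatic ring.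

The closest guide is an at least 3.5-fold lower number from compound 2 to compound 3 (0.54 log units; beyond the scatter), with methyl in place of fluoro on an aromatic carbon. A second relevant change is a 3.0-fold lower number from compound 1 to compound 3 (0.48 log units; beyond the scatter), with 3-methylphenyl in place of 2-chlorophenyl. Within the data shown here, both lead to compound 3, the only measured compound with a methylphenyl group. By contrast, an at least 1.1-fold higher number from compound 1 to compound 2 (0.07 log units; that floor lies within the scatter) gives little guidance. Among the measured compounds shown here, no measured compound carries 4-methylphenyl, so carrying these steps over to compound 4 remains uncertain.

A step of similar size toward a lower number is nevertheless expected in this assay. The expected change is an at least 2.9-fold lower number from compound 2 to compound 4 (0.46 log units; beyond the scatter). For compound 4 the estimated value is 17000 nM, with an expected range from 6000 nM to 45000 nM.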

Compound 4, half-maximal inhibitory concentration: 13800 nM
Compound 4: middle estimate off by 1.2-fold (0.09 log units), on the high side; the range from low to high includes it.
By their numbers in this assay, from the lowest: compounds 4 and 3 (each within the scatter of the next); then compound 1. At a limit, above all of these: compound 2.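

In this assay, among these compounds, the 4-methylphenyl and 3-methylphenyl groups on the oxygen cannot be told apart, which the earlier compounds could not show with only one methylphenyl group among them: a 1.0-fold lower number from compound 3 to compound 4 (0.01 log units; within the scatter). Compound 4 also separates from the 2-chlorophenyl and 3-fluorophenyl compounds, with a 3.1-fold lower number from compound 1 to compound 4 (0.49 log units; beyond the scatter) and an at least 3.6-fold lower number from compound 2 to compound 4 (0.55 log units; beyond the scatter), so both methylphenyl compounds now read lower than both halogen-bearing ones, and none of the four compounds goes against this. The step from compound 2 gives only a floor, because compound 2 stands at a limit rather than at a number: the limit of > 50000 nM in this assay, at which 1 of the 4 values shown sits.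

The compounds shown leave open whether the methyl group itself matters here or whether the chloro and fluoro groups are what set those two compounds apart, and a plain phenyl group would bear on that question. As far as these compounds go, it also remains open how an ethyl or methoxy group in place of the methyl on the phenyl ring would read, and the true size of the step from compound 2 stays unknown.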